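A few compounds are considered here, and "the series" means these few. Any claim that something is new, unique, unknown or untested is made for them only; others in the source may bear on it.

Measured in a functional assay on HO8910 cells (Homo sapiens) for inhibition, read by MTT assay, with a stated time of 24 h, tested at 0.1 ug/mL; a higher number here means more inhibition of growth at the concentration tested, a lower number less inhibition of growth:
- compound 1 `O=C(CCCCC1CCSS1)Nc1ccc(Cl)cn1`: "not active" (no number reported)
- compound 2 `CC(=O)SCCC(CCCCC(=O)Nc1ccccc1)SC(C)=O`: 8.33%

Among the compounds with values here, compound 2 carries the only number in this small set, since compound 1 was reported without one. Compound 3 `CC(=O)SCCC(CCCCC(=O)Nc1ccc(Cl)cc1)SC(C)=O` departs from compound 2 by chloro in place of hydrogen on an aromatic carbon, with chloro in place of hydrogen on an aromatic carbon, para to a large group. Within the data shown here, no measured pair differs in a single place, so the data offer no step to lean on and no direction is favoured. The expected step is a number 1.7 percentage points higher from compound 2 to compound 3 (within the scatter), none beyond the scatter. For compound 3 the estimated value is 10%, with a range of 2% to 22%.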

Compound 3, percent growth inhibition at one concentration: 1.81%
Estimate against measurement, compound 3: 8.2 percentage points above; the whole stated range lies above it.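

In this assay, within the data shown here, the change from phenyl to 4-chlorophenyl gives the first comparison in this set that differs in one place, with a number 6.5 percentage points lower from compound 2 to compound 3 (within the scatter). At this position, para to a large group, chloro and hydrogen therefore cannot be told apart on this read-out. Nothing available here bears on why this is so. From the compounds shown here alone, it remains open whether an amine, a methoxy group or a carboxylic acid at the same position would separate from hydrogen beyond the usual scatter.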